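Methyl on the second benzoyl ring of compound 1

The compounds below may be only part of what the source reports. "The series", "measured", "known", "first", "only" and "open" are said of these compounds alone.

Among the compounds with values here, compound 1 `CC(C)(C)N(NC(=O)c1ccccc1)C(=O)c1ccccc1Cl` holds the lower of the two numbers so far: in an assay on cells for agonist activity at ecdysone receptor (Bombyx mori), read by a luciferase reporter, with a stated time of 24 h (on this read-out higher numbers stand for an effect only at larger amounts of compound and lower numbers for an effect already at smaller amounts), compound 1 gives 75.9 nM. Compound 2 `Cc1ccccc1C(=O)N(NC(=O)c1ccccc1)C(C)(C)C` differs from it by methyl in place of chloro on an aromatic carbon, and in this assay compound 2 gives 224 nM, so that a 3.0-fold higher number from compound 1 to compound 2 (0.47 log units; beyond the scatter) and compound 1 serves as the reference point. Compound 3 `Cc1cccc(C(=O)NN(C(=O)c2ccccc2Cl)C(C)(C)C)c1` keeps the chloro of compound 1 and carries the change methyl in place of hydrogen on an aromatic carbon on the other aromatic ring, meta to a large group. Within the data shown here, no measured step touches this position: the only step in hand, a 3.0-fold higher number from compound 1 to compound 2 (0.47 log units; beyond the scatter), swaps chloro for methyl on a different aromatic carbon and takes a group away rather than adding one, so it offers no direct guide to the new methyl. Among the measured compounds shown here, with no bearing step, no shift beyond the scatter is expected for compound 3 in this assay, in either direction. The estimate for compound 3 is accordingly 80 nM, with a range from 35 nM to 190 nM, which corresponds to an expected step of a 1.1-fold higher number from compound 1 to compound 3 (0.02 log units; within the scatter).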

Compound 3, half-maximal effective concentration: 603 nM
The estimate for compound 3 lay 7.5-fold (0.88 log units) below the measured number; the measured number lies above the stated range.
By their numbers in this assay, from the lowest: compound 1; then compound 2; then compound 3.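

Phenyl to 3-methylphenyl on the core of compound 1 is not a silent change: in this assay this single added methyl gives a 7.9-fold higher number from compound 1 to compound 3 (0.90 log units; beyond the scatter) and so shows that this site, meta to a large group, responds to substitution. Within the data shown here, until now the only reading came from the other aromatic ring, where the step was a 3.0-fold higher number from compound 1 to compound 2 (0.47 log units; beyond the scatter) and a chloro was exchanged rather than a hydrogen replaced, so the series now has a change on each ring, both going to higher numbers and both leaving compound 1 with the lowest number of the three. The compounds and data in hand offer nothing that accounts for the rise at this site.

Still open, from the compounds shown here alone, is whether the rise belongs to methyl as such or to any group at this site, a question that a fluorine, a methoxy group or an amine in the same place would address. Also open, going by these compounds, is whether methyl elsewhere on this ring gives a similar step, and whether the step at this site keeps its size when the chloro of compound 1 is exchanged for the methyl of compound 2.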